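Replacing the Aryl Group on a Shared Core

This account rests on a few compounds, and the source may have more. Where it says the series, first, only, none or still open, it means among the compounds named here.

Measured compounds:
compound 1 `COc1ccc(C2C(OC(C)=O)C(=O)N2c2cc(OC)c(OC)c(OC)c2)cc1N` — 73.1 nM
compound 2 `COc1ccc(C2C(OC(C)=O)C(=O)N2c2cc(OC)c(OC)c(OC)c2)cn1` — > 1000 nM
compound 3 `COc1ccc(C2C(O)C(=O)N2c2cc(OC)c(OC)c(OC)c2)cn1` — > 1000 nM

In a functional assay on IMR-32 cells (Homo sapiens) for cytotoxicity (a lower number here means a stronger inhibitor, a higher number a weaker inhibitor), compound 1 gives 73.1 nM. For compound 2 the value is a limit of the assay, > 1000 nM. For compound 3 the value is likewise a limit, > 1000 nM. Compound 3 therefore stands at the weak end of what is shown, at the limit of > 1000 nM in this assay, at which 2 of the 3 values shown sit.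

Compound 4 `COc1cc(N2C(=O)C(O)C2c2ccc([N+](=O)[O-])o2)cc(OC)c1OC` differs from compound 3 in one place: 5-nitrofuran-2-yl in place of 6-methoxypyridin-3-yl on a saturated ring carbon. Within the data shown here, one measured step touches the same saturated ring carbon: an at least 13-fold higher number from compound 1 to compound 2 (1.13 log units; beyond the scatter), a large loss when that aryl group was exchanged. The other step, a step that the two limits leave unreadable from compound 2 to compound 3, cannot be sized. Among the measured compounds shown here, no measured step tests the 5-nitrofuran-2-yl group itself, so the direction of this change is open. Given that compound 3 sits at a limit, compound 4 is expected to stay weak, with an estimated step that the limit leaves unreadable from compound 3 to compound 4. The estimate for compound 4 is 2000 nM, in a range from 300 nM to 10000 nM.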

Compound 4, half-maximal inhibitory concentration: > 1000 nM
Compound 4: no number, only a limit (the forecaster's own chance of this, stated with the estimate: 60%); the middle value is on the limit's open side.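

Compound 4 gives only a limit of the assay, > 1000 nM, and compound 3 also has only a limit, so no step can be read between them. The compounds shown leave open whether 5-nitrofuran-2-yl or 6-methoxypyridin-3-yl gives the stronger inhibitor on this shared core.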